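Sulfonyl aryl variation on a shared piperidinyl-quinoline core

The source may report more compounds than this note shows. Statements on the series, on what has been measured and on what is new or still open speak of the compounds shown alone.

Compounds measured so far, with their values in an assay on isolated protein for displacement of a labelled ligand from metabotropic glutamate receptor 5 (Homo sapiens), with a stated time of 60 min, tested at 1 uM; a lower number here means less inhibition, a higher number more inhibition at the concentration tested (going by the name of the read-out):
compound 1 `CC1CCN(c2c(S(=O)(=O)c3ccc(F)cc3)cnc3ccc(Cl)cc23)CC1` gives 89%;
compound 2 `COc1ccc(S(=O)(=O)c2cnc3ccc(Cl)cc3c2N2CCC(C)CC2)cc1OC` gives 61%;
compound 3 `CC1CCN(c2c(S(=O)(=O)c3ccc(F)c(F)c3)cnc3ccc(Cl)cc23)CC1` gives 72%.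

Compound 3 stands second highest of the three numbers. Its nearest neighbour is compound 2, which lies lower, beyond the scatter, as the step of a number 11 percentage points higher from compound 2 to compound 3 (beyond the scatter) shows; its furthest is compound 1, which lies higher, again beyond the scatter, as seen in a number 17 percentage points lower from compound 1 to compound 3 (beyond the scatter).

The new compound, compound 4 `CC1CCN(c2c(S(=O)(=O)c3cccc(C#N)c3)cnc3ccc(Cl)cc23)CC1`, differs from compound 3 in one place: 3-cyanophenyl in place of 3,4-difluorophenyl on a sulfonyl sulfur.

Going by the values given here, three measured steps bear on this change, since each of them alters the aryl group on the sulfonyl sulfur while the core is held fixed. From compound 1 to compound 2 the number fell by a number 28 percentage points lower from compound 1 to compound 2 (beyond the scatter); from compound 1 to compound 3 by a number 17 percentage points lower from compound 1 to compound 3 (beyond the scatter); and from compound 2 to compound 3 it rose by a number 11 percentage points higher from compound 2 to compound 3 (beyond the scatter). All three are modest and beyond the scatter, so another aryl change at this position is expected to move the number modestly as well, in either direction. Because a number 17 percentage points lower from compound 1 to compound 3 (beyond the scatter) and the other two aryl steps all stayed in a modest band, compound 4 is expected to give roughly 66%, ranging from 42% to 86%, which is expected to mean a step of a number 6 percentage points lower from compound 3 to compound 4 (within the scatter).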

Compound 4, a percentage reported as inhibition, at one concentration (the size of the read-out at that concentration, not a potency): 90%
Beside the measured number, compound 4's estimate is 24 percentage points below it, outside the stated range (above it).
By their numbers in this assay, from the lowest: compound 2; then compound 3; then compounds 1 and 4 (each within the scatter of the next).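

In this assay, putting 3-cyanophenyl on the sulfonyl sulfur gives a number 18 percentage points higher from compound 3 to compound 4 (beyond the scatter) and also a number 29 percentage points higher from compound 2 to compound 4 (beyond the scatter), so the aryl group at this position can raise the number as well as lower it, whereas every earlier step away from 4-fluorophenyl had lowered it. Against that group the change gives a number 1 percentage points higher from compound 1 to compound 4 (within the scatter), which means that a ring carrying a nitrile and a ring carrying a single fluorine stand level here, and 4-fluorophenyl is no longer alone at the top of the series. Nothing measured here accounts for these differences between the aryl groups.

Still open, going by these compounds, is how an aryl ring carrying an amine or a carboxylic acid would read in this assay on this core. Equally open, on these data alone, is whether a longer alkyl chain in place of the aryl ring on the sulfonyl sulfur would keep the number up.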